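The source may report more compounds than this note shows. Statements on the series, on what has been measured and on what is new or still open speak of the compounds shown alone.

Measured compounds in a functional assay on LOX IMVI cells (Homo sapiens) for inhibition, read by sulforhodamine B assay, with a stated time of 48 h; a lower number here means that less compound is tolerated, a higher number that more compound is tolerated:
- compound 1, `O=C(Nc1cccc(-n2cc(-c3ccncc3)c(-c3ccc(Cl)c(O)c3)n2)c1)Nc1cccc(C(F)(F)F)c1`, gives 32400 nM
- compound 2, `O=C(Nc1cccc(-n2cc(-c3ccncc3)c(-c3ccc(Cl)c(O)c3)n2)c1)Nc1ccc(Cl)c(Cl)c1`, gives 15000 nM
- compound 3, `COc1cc(-c2nn(-c3cccc(NC(=O)Nc4ccc(Cl)c(C(F)(F)F)c4)c3)cc2-c2ccncc2)ccc1Cl`, gives 17900 nM

Compound 3 stands second highest of the three numbers in this assay; its nearest neighbour is compound 2, within the scatter, and its furthest is compound 1, also within the scatter. Within the data shown here, the only single-place step measured is a 2.2-fold lower number from compound 1 to compound 2 (0.33 log units; beyond the scatter), which concerns the aryl on the amide-type nitrogen and not the part changed here.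

Compound 4, `O=C(Nc1cccc(-n2cc(-c3ccncc3)c(-c3ccc(Cl)c(O)c3)n2)c1)Nc1ccc(Cl)c(C(F)(F)F)c1`, differs from compound 3 by hydrogen in place of methyl on an oxygen on an aromatic ring. Among the measured compounds shown here, no measured pair shows this methoxy-to-hydroxy change in isolation, so no step bears on it directly. Compounds 1 and 2 both carry the hydroxy form and sit within the scatter of compound 3, which carries the methoxy form; the three numbers together give no sign that this position moves the number.

Compound 4 is therefore expected to stay close to compound 3, with an estimated step of a 1.1-fold lower number from compound 3 to compound 4 (0.05 log units; within the scatter). The estimate for compound 4 in this assay is 16000 nM, within a range of 8000 nM to 35000 nM.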

Compound 4, concentration lethal to 50% of the cells: 2390 nM
The estimate for compound 4 lay 6.7-fold (0.83 log units) above the measured number; the whole stated range lies above it.
By their numbers in this assay, from the lowest: compound 4; then compounds 2, 3 and 1 (each within the scatter of the next, the first and the last beyond it).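

In this assay, among these compounds, methoxy to hydroxy gives a 7.5-fold lower number from compound 3 to compound 4 (0.87 log units; beyond the scatter) and is the first isolated reading of this change, showing that this position can move the number. Compounds 1 and 2 also carry the hydroxy form, yet with that form held fixed, trifluoromethyl in place of chloro gives a 6.3-fold lower number from compound 2 to compound 4 (0.80 log units; beyond the scatter) and chloro in place of hydrogen gives a 14-fold lower number from compound 1 to compound 4 (1.13 log units; beyond the scatter), so the hydroxy form does not bring the low number of compound 4 on its own. Nothing available explains the size of these steps.

Still open, from the compounds shown here alone, is whether methoxy to hydroxy gives a step of similar size with the 3,4-dichlorophenyl or 3-(trifluoromethyl)phenyl group on the amide-type nitrogen. Also open, going by these compounds, is how a longer chain such as ethyl on that oxygen, or an amine in place of the hydroxy, would place a compound.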